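The source may hold more compounds than are shown below. What is called first, only, known or untested is meant among the compounds shown, and "the series" means these compounds.

Compound 1 `CCCCS(=O)(=O)Oc1ccc(/C=C/C(=O)Nc2ccc(C)cc2)cc1OC` gives 26800 nM in a toxicity assay on L02 cells (Homo sapiens) for cytotoxicity, read by MTT assay, with a stated time of 24 h (on this read-out higher numbers stand for lower toxicity in this test and lower numbers for higher toxicity in this test), as its measured result. Two relatives give the context: compound 2 `CCCCOC(=O)/C=C/c1ccc(OS(=O)(=O)c2ccc(Cl)cc2)c(OC)c1` gives 14000 nM and compound 3 `COc1cc(/C=C/C(=O)Nc2ccc(I)cc2)ccc1OS(=O)(=O)c1ccc(Cl)cc1` gives 39400 nM in this assay as well. Compound 1 lies within the usual scatter of both, so it has no firm rank against either one. Only compound 2 and compound 3 stand clearly apart.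

Compound 4 `CCCCS(=O)(=O)Oc1ccc(/C=C/C(=O)OCCC)cc1OC` changes one group of compound 1 on the carbonyl carbon, with propoxy in place of (4-methylphenyl)amino on a carbonyl carbon as the counted difference, so that propoxy replaces (4-methylphenyl)amino and an amide becomes an ester.

For the measured compounds named here, one measured step bears on this swap. With (4-iodophenyl)amino in place of butoxy on a carbonyl carbon, the data show a 2.8-fold higher number from compound 2 to compound 3 (0.45 log units; beyond the scatter) as a modest change. Compound 4 makes the same kind of swap in reverse, so a step of similar size towards a lower number is expected. This rests on a single pair, whose groups are not identical to those here and which also differs from compound 1 elsewhere in the molecule, so the expectation is loose.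

The estimated change is a 2.7-fold lower number from compound 1 to compound 4 (0.43 log units; beyond the scatter) in this reading. Compound 4 is expected at 10000 nM with an estimated range from 4500 nM to 23000 nM in this assay once tested.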

Compound 4, half-maximal cytotoxic concentration: 61800 nM
The estimate for compound 4 lay 6.2-fold (0.79 log units) below the measured number; the measured number lies above the stated range.
By their numbers in this assay, from the lowest: compounds 2, 1, 3 and 4 (each within the scatter of the next, the first and the last beyond it).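

In this assay the swap on this carbonyl carbon gives a 2.3-fold higher number from compound 1 to compound 4 (0.36 log units; beyond the scatter), so here the ester with propoxy shows lower toxicity in this test than the amide with (4-methylphenyl)amino. The earlier pair pointed the other way, with a 2.8-fold higher number from compound 2 to compound 3 (0.45 log units; beyond the scatter) on going from an ester to an amide, so among the compounds shown neither ester nor amide goes with the higher number in every case. A change of this kind at this position therefore cannot be read as a fixed step that carries over unchanged from one compound pair to another, and no measurement at hand explains why the two pairs differ.

The two pairs differ in their carbonyl groups and also elsewhere in the molecule, so the compounds shown leave open whether the opposite directions come from the particular groups swapped or from the rest of the structure. They also leave open where the number would fall with a carboxylic acid, or with a longer chain such as hexyloxy, on this carbonyl carbon.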